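A few compounds are considered here, and "the series" means these few. Any claim that something is new, unique, unknown or untested is made for them only; others in the source may bear on it.

Three compounds share one core and differ only in the group on the carbonyl carbon of the amide. Compound 1 `CCCC(=O)N1CCC(NS(=O)(=O)c2ccc(NC(=O)c3cccc(C)c3)c3ccccc23)CC1` carries a 3-methylphenyl there and gives 5.1 nM in an in vitro functional assay on CHO/Galpha16 cells for antagonist activity at C-C chemokine receptor type 8 (Homo sapiens), read by FLIPR; a lower number here means a stronger inhibitor, a higher number a weaker inhibitor. Compound 2 `CCCC(=O)N1CCC(NS(=O)(=O)c2ccc(NC(=O)c3cc(C)oc3C(F)(F)F)c3ccccc23)CC1` gives 46.9 nM, and compound 3 `CCCC(=O)N1CCC(NS(=O)(=O)c2ccc(NC(=O)c3nccn3C)c3ccccc23)CC1` gives 20.4 nM. Compound 3 thus stands second highest of the three: it is a 4.0-fold higher number from compound 1 to compound 3 (0.60 log units; beyond the scatter) and a 2.3-fold lower number from compound 2 to compound 3 (0.36 log units; beyond the scatter).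

Compound 4 `CCCC(=O)N1CCC(NS(=O)(=O)c2ccc(NC(=O)c3cc(C)nc(Cl)c3)c3ccccc23)CC1` is the one not yet measured. Compared with compound 3, the change is 2-chloro-6-methylpyridin-4-yl in place of 1-methyl-1H-imidazol-2-yl on a carbonyl carbon.

All three measured steps bear on this position. Replacing the 3-methylphenyl by a five-membered heteroaromatic ring made the number worse, a 9.2-fold higher number from compound 1 to compound 2 (0.96 log units; beyond the scatter) and a 4.0-fold higher number from compound 1 to compound 3 (0.60 log units; beyond the scatter), while the swap between the two five-membered rings was smaller, a 2.3-fold lower number from compound 2 to compound 3 (0.36 log units; beyond the scatter). A six-membered ring with one hetero atom resembles the 3-methylphenyl of compound 1 more than the ring of compound 3 does, so a modest step toward lower numbers is expected, a 2.0-fold lower number from compound 3 to compound 4 (0.31 log units; beyond the scatter). Compound 4 is therefore estimated at 10 nM, with a range from 3 nM to 35 nM.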

Compound 4, half-maximal inhibitory concentration: 43.9 nM
Compound 4: middle estimate off by 4.4-fold (0.64 log units), on the low side; measured number outside the range, above it.
By their numbers in this assay, from the lowest: compound 1; then compound 3; then compounds 4 and 2 (each within the scatter of the next).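

A six-membered aromatic ring with one hetero atom does not by itself bring back the low number of the 3-methylphenyl group: in this assay the 2-chloro-6-methylpyridin-4-yl group gives an 8.6-fold higher number from compound 1 to compound 4 (0.93 log units; beyond the scatter). It also falls behind the 1-methyl-1H-imidazol-2-yl group, with a 2.2-fold higher number from compound 3 to compound 4 (0.33 log units; beyond the scatter), yet it cannot be told apart from the 5-methyl-2-(trifluoromethyl)furan-3-yl group, with a 1.1-fold lower number from compound 2 to compound 4 (0.03 log units; within the scatter), so among these compounds ring size alone does not set the order. No measurement here explains these differences.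

On these data alone, the chlorine and the methyl group enter together with the pyridine ring, so their separate shares in this step stay unknown. A plain pyridin-4-yl or a 3-chlorophenyl group on the same carbonyl carbon would help to separate the ring from its substituents.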